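Replacing diethylamino with pyrrolidin-1-yl on the shared core

The compounds below may be only part of what the source reports. "The series", "measured", "known", "first", "only" and "open" are said of these compounds alone.

Of the compounds shown here, three built on one core have been tested in a functional assay on DU-145 cells (Homo sapiens) for cytotoxicity, read by MTT assay, with a stated time of 72 h; a higher number here means a weaker inhibitor, a lower number a stronger inhibitor. There, compound 1 `O=c1ccc2nc(-c3ccccc3)nn(-c3ccccc3)c-2c1` gives 230 nM, compound 2 `Nc1cc2nc(-c3ccccc3)nn(-c3ccccc3)c-2cc1=O`, with an amino group on an aromatic carbon, gives 1830 nM, and compound 3 `CCN(CC)c1cc2nc(-c3ccccc3)nn(-c3ccccc3)c-2cc1=O`, with diethylamino on that carbon, gives 3110 nM. Both groups take the place of a hydrogen in compound 1, and both steps lie beyond the scatter: an 8.0-fold higher number from compound 1 to compound 2 (0.90 log units; beyond the scatter) and a 14-fold higher number from compound 1 to compound 3 (1.13 log units; beyond the scatter). Compound 3 therefore stands well behind compound 1 but level with compound 2, as a 1.7-fold higher number from compound 2 to compound 3 (0.23 log units; within the scatter) lies within the scatter.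

Compound 4 `O=c1cc2n(-c3ccccc3)nc(-c3ccccc3)nc-2cc1N1CCCC1` differs from compound 3 in a single group: pyrrolidin-1-yl in place of diethylamino on an aromatic carbon. In words, pyrrolidin-1-yl stands in place of diethylamino on an aromatic carbon. For the measured compounds named here, no measured step shows a ring at this carbon, so the evidence is indirect. The closest guide is a 1.7-fold higher number from compound 2 to compound 3 (0.23 log units; within the scatter), where exchanging one nitrogen-linked group for another changed little. Nothing here points to a step beyond the scatter, and the estimate is a 1.2-fold lower number from compound 3 to compound 4 (0.09 log units; within the scatter), which is expected to stay within it. In this assay the expected value for compound 4 is 2500 nM, with an estimated range from 1000 nM to 6000 nM.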

Compound 4, half-maximal inhibitory concentration: 2460 nM
Estimate against measurement, compound 4: 1.0-fold (0.01 log units) above; measured number inside the range.
By their numbers in this assay, from the lowest: compound 1; then compounds 2, 4 and 3 (each within the scatter of the next).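

In this assay tying the two ethyl chains of diethylamino into the pyrrolidin-1-yl ring, with the same count of heavy atoms, leaves the result at this carbon level (a 1.3-fold lower number from compound 3 to compound 4 (0.10 log units; within the scatter)). The ring also stands level with the plain amino group (a 1.3-fold higher number from compound 2 to compound 4 (0.13 log units; within the scatter)), so neither the ring nor the size of the group separates these compounds. Against the hydrogen of compound 1, the ring shows a clear loss (an 11-fold higher number from compound 1 to compound 4 (1.03 log units; beyond the scatter)), and together with compounds 2 and 3 this ties the loss to having any of these three nitrogen-linked groups on this carbon, not to which one is there.

Going by these compounds, whether the same holds for a group joined through another atom, such as methoxy or a chlorine atom, or for a six-membered ring such as morpholine, stays open. Why a nitrogen-linked group here goes with a weaker result also stays open, since no measurement at hand bears on the cause.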